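The compounds below may be only part of what the source reports. "The series", "measured", "known", "first", "only" and "open" are said of these compounds alone.

Measured so far:
- compound 1, `Nc1nc(-c2ccc(CO)cc2)nc2sc(-c3ccccc3)nc12`: > 30000 nM
- compound 2, `N#Cc1cccc(-c2nc(N)c3nc(-c4ccccc4)sc3n2)c1`: > 30000 nM

Compound 1 is the starting point. In a functional assay on CHO cells for antagonist activity at adenosine receptor A2b (Homo sapiens), read by cAMP accumulation, with a stated time of 10 min (on this read-out lower numbers stand for stronger inhibition and higher numbers for weaker inhibition), compound 1 gives > 30000 nM, and this is a limit of the assay rather than a measured number. Compound 2 gives > 30000 nM in this assay, again a limit and not a number. Because of the limit of > 30000 nM in this assay, at which 2 of the 2 values shown sit, compound 1 cannot be placed on a scale against compound 2: the step that the two limits leave unreadable from compound 1 to compound 2 has no readable size, and it concerns a change on the other aromatic carbon of the shared core, the 3-cyanophenyl in place of 4-(hydroxymethyl)phenyl.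

The compound not yet measured is compound 3, `Nc1nc(-c2ccc(CO)cc2)nc2sc(-c3ccco3)nc12`. It differs from compound 1 in furan-2-yl in place of phenyl on an aromatic carbon. Going by the values given here, no measured step touches this position, and the one measured step, from compound 1 to compound 2, is unreadable, so nothing here points to a gain or a loss beyond the scatter. The most that can be said is that the shared core has so far given only limits. Compound 3 is therefore expected to give about 30000 nM in this assay, with a range from 8000 nM to 100000 nM, which means an expected step of a number no higher from compound 1 to compound 3 (the limit leaves the size open) and most likely another limit.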

Compound 3, half-maximal inhibitory concentration: > 30000 nM
Compound 3 ended at the assay's limit; the forecaster's own chance of this, stated with the estimate: 70%; the middle value lies on the limit itself.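

No size can be read for the step from compound 1 to compound 3, furan-2-yl in place of phenyl, since both values are limits and not numbers: the limit of > 30000 nM in this assay, at which 3 of the 3 values shown sit.

The compounds shown leave open whether any change on the shared core gives a value that can be read as a number in this assay.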